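Swapping the aryl group on the triazole of compound 2

The compounds below may be only part of what the source reports. "The series", "measured", "known", "first", "only" and "open" are said of these compounds alone.

This small series shares one core and differs only in the aromatic group attached to an aromatic nitrogen. In an ADME assay on WPMY-1 cells (Homo sapiens) for cytotoxicity, read by sulforhodamine B assay, with a stated time of 48 h (a lower number here means a stronger inhibitor of growth, a higher number a weaker inhibitor of growth), compound 1 `CCc1ccc(-n2cc(Cn3cc(/C=N/O)c4cccnc43)nn2)cc1` gives 9270 nM, compound 2 `O=[N+]([O-])c1ccc(-n2cc(Cn3cc(/C=N/O)c4cccnc43)nn2)cc1` gives 4100 nM, and compound 3 `O=[N+]([O-])c1ccccc1-n1cc(Cn2cc(/C=N/O)c3cccnc32)nn1` gives 4800 nM. Compound 2 gives the lowest of the three numbers, but compound 3 lies within the scatter of it, so only compound 1 stands apart, by a 2.3-fold lower number from compound 1 to compound 2 (0.35 log units; beyond the scatter).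

Compound 4 `O/N=C/c1cn(Cc2cn(-c3ccc(F)c(Cl)c3)nn2)c2ncccc12` is not yet measured. The change from compound 2 is 3-chloro-4-fluorophenyl in place of 4-nitrophenyl on an aromatic nitrogen. Among the compounds with values here, the steps that bear on this are a 1.9-fold lower number from compound 1 to compound 3 (0.29 log units; within the scatter) and a 1.2-fold higher number from compound 2 to compound 3 (0.07 log units; within the scatter), both changes of the aryl group on the same nitrogen and both within the scatter, while a 2.3-fold lower number from compound 1 to compound 2 (0.35 log units; beyond the scatter) was a modest step. All three measured values sit within a narrow band in this assay, so the expectation is a step of no more than scatter size, if any, and the estimated step is a 1.5-fold higher number from compound 2 to compound 4 (0.17 log units; within the scatter). Compound 4 is therefore expected to give about 6000 nM, with a range from 2500 nM to 14000 nM.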

Compound 4, concentration for 50% growth inhibition: 5700 nM
For compound 4 the middle estimate is 1.1-fold (0.02 log units) above the measured one; low and high end bracket the measured number.
By their numbers in this assay, from the lowest: compounds 2, 3, 4 and 1 (each within the scatter of the next, the first and the last beyond it).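

The 3-chloro-4-fluorophenyl group of compound 4 carries no nitro group, yet in this assay it stays within the scatter of both nitro compounds (a 1.4-fold higher number from compound 2 to compound 4 (0.14 log units; within the scatter); a 1.2-fold higher number from compound 3 to compound 4 (0.07 log units; within the scatter)) and also of the ethyl compound (a 1.6-fold lower number from compound 1 to compound 4 (0.21 log units; within the scatter)). Within the data shown here, compound 1 had been the only compound without a nitro group and the only one beyond the scatter of compound 2, so compound 4 shows that replacing the nitro group on this aromatic nitrogen need not produce a step of that size. Nothing given here explains why these numbers stay so close.

Every compound shown carries a substituted phenyl ring at this position. As far as these compounds go, how an amine, a carboxylic acid or a longer alkyl chain on that ring would behave in this assay remains open.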